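The compounds below may be only part of what the source reports. "The series", "measured", "known", "first", "only" and "open" are said of these compounds alone.

Measured in a functional assay on B16 cells (Mus musculus) for antiproliferative activity, read by MTT assay, with a stated time of 24 h; on this read-out lower numbers stand for stronger inhibition and higher numbers for weaker inhibition:
compound 1 `COc1cc(OC)c(-c2coc3cc(OCC=C(C)C)ccc3c2=O)cc1OC`: 1090 nM
compound 3 `COc1cc(OC)c(-c2coc3cc(OCc4ccccc4Cl)ccc3c2=O)cc1OC`: 4180 nM
compound 2 `COc1cc(OC)c(-c2coc3cc(OCC(=O)c4cccc(C(F)(F)F)c4)ccc3c2=O)cc1OC`: > 10000 nM

For compound 2 the value is a limit of this assay, not a number (the limit of > 10000 nM in this assay, at which 1 of the 3 values shown sits). Among the numbers shown, compound 1 stands lowest, so it inhibits most strongly; the nearest measured neighbour lies a 3.8-fold higher number from compound 1 to compound 3 (0.58 log units; beyond the scatter). Compound 4 `COc1cc(OC)c(-c2coc3cc(OCc4ccccc4Br)ccc3c2=O)cc1OC` differs from compound 1 by 2-bromophenyl in place of 2-methylprop-1-en-1-yl on a saturated chain carbon bound to an oxygen on an aromatic ring. The closest measured step is the change to 2-chlorophenyl at the same place, which gave a 3.8-fold higher number from compound 1 to compound 3 (0.58 log units; beyond the scatter); the 2-bromophenyl change is of the same kind, so a modest rise of similar size is expected, a 3.7-fold higher number from compound 1 to compound 4 (0.56 log units; beyond the scatter). Compound 4 is therefore estimated at 4000 nM, with a likely range from 1500 nM to 10000 nM.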

Compound 4, half-maximal inhibitory concentration: 8900 nM
For compound 4 the middle estimate is 2.2-fold (0.35 log units) below the measured one; the measured number falls inside the stated range.
By their numbers in this assay, from the lowest: compound 1; then compound 3; then compound 4. At a limit, above all of these: compound 2.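

Bromo in place of chloro on an aromatic carbon gives a 2.1-fold higher number from compound 3 to compound 4 (0.33 log units; beyond the scatter), a modest step towards weaker inhibition. Compared with the 3-methylbut-2-en-1-yl group of compound 1, the 2-bromobenzyl group gives an 8.2-fold higher number from compound 1 to compound 4 (0.91 log units; beyond the scatter), which places both halogen-bearing benzyl compounds on the weaker side of compound 1. Compound 2 stands at a limit, so the step of an at least 1.1-fold lower number from compound 2 to compound 4 (0.05 log units; that floor lies within the scatter) is only a floor and cannot be read as a size: the limit of > 10000 nM in this assay, at which 1 of the 4 values shown sits.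

On these data alone, whether an unsubstituted benzyl, a 2-fluorobenzyl or a longer chain such as geranyl would come closer to compound 1 remains open.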